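A few compounds are considered here, and "the series" means these few. Any claim that something is new, unique, unknown or untested is made for them only; others in the source may bear on it.

Among the measured compounds shown here, in a functional assay on QGY-7703 cells (Homo sapiens) for cytotoxicity, read by MTT assay, with a stated time of 24 h (on this read-out higher numbers stand for weaker inhibition and lower numbers for stronger inhibition), compound 1 `CN1C/C(=C\c2cccnc2)C(=O)/C(=C/c2ccccc2C(F)(F)F)C1` gives 2910 nM and compound 2 `CN1C/C(=C\c2ccncc2)C(=O)/C(=C/c2ccccc2C(F)(F)F)C1` gives 4500 nM, so compound 1 stands within the scatter of its only measured neighbour. Compound 3 `O=C1/C(=C/c2cccnc2)CNC/C1=C\c1ccccc1C(F)(F)F` differs from compound 1 by hydrogen in place of methyl on an amine nitrogen in a ring. For the measured compounds named here, the sole measured step, a 1.5-fold higher number from compound 1 to compound 2 (0.19 log units; within the scatter), concerns pyridin-4-yl in place of pyridin-3-yl, and no measured pair varies that nitrogen. Support is therefore thin, and no step beyond the scatter is expected in this assay. The expected step is a 1.0-fold lower number from compound 1 to compound 3 (0.02 log units; within the scatter). For compound 3 the estimated value is 2800 nM, with an expected range of 1000 nM to 8000 nM.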

Compound 3, half-maximal inhibitory concentration: 3800 nM
The estimate for compound 3 lay 1.4-fold (0.13 log units) below the measured number; measured number inside the range.
By their numbers in this assay, from the lowest: compounds 1, 3 and 2 (each within the scatter of the next).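

In this assay, the amine nitrogen in a ring now has its first measured change: hydrogen in place of methyl gives a 1.3-fold higher number from compound 1 to compound 3 (0.12 log units; within the scatter). The methyl group is therefore not required for compound 3 to remain within the scatter of compound 1, whereas the earlier pair varied only the pyridine attachment. No measured evidence bears on this result.

Open, going by these compounds, is how a benzyl or acetyl group on this nitrogen would read in this assay. Also open, on these data alone, is whether the same exchange gives a similar step with pyridin-4-yl in the compound 2 setting.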